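Thiophen-2-yl to Phenyl on the Shared Core

The source may report more compounds than this note shows. Statements on the series, on what has been measured and on what is new or still open speak of the compounds shown alone.

Two members of the series carry numbers in a functional assay on HepG2 cells (Homo sapiens) for antiproliferative activity, read by MTT assay; a lower number here means a stronger inhibitor, a higher number a weaker inhibitor. Compound 1 `Nc1c(C(=O)NC2CCCC2)oc2nc(-c3ccccc3)cc(C(F)(F)F)c12` gives 32400 nM. Compound 2 `Nc1c(C(=O)N/N=C/c2ccc(Cl)cc2)oc2nc(-c3cccs3)cc(C(F)(F)F)c12` gives 8100 nM, the lowest of the two numbers; compound 1 sits at a higher number, and the gap between compounds 1 and 2 lies beyond the scatter. Compounds 1 and 2 differ in more than one place, so no single step can be read from that pair. Compound 3 `Nc1c(C(=O)N/N=C/c2ccc(Cl)cc2)oc2nc(-c3ccccc3)cc(C(F)(F)F)c12` is the next to be measured. It differs from compound 2 by phenyl in place of thiophen-2-yl on an aromatic carbon. Among the compounds with values here, no measured pair isolates this change, so there is no measured step to lean on. The step of a 1.4-fold higher number from compound 2 to compound 3 (0.13 log units; within the scatter) is expected to stay within the scatter, with a lean toward a higher number if it moves at all. Compound 3 is therefore estimated at 11000 nM, with a range from 4000 nM to 30000 nM.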

Compound 3, half-maximal inhibitory concentration: 12100 nM
Beside the measured number, compound 3's estimate is 1.1-fold (0.04 log units) below it, within the range that was stated.
By their numbers in this assay, from the lowest: compounds 2 and 3 (each within the scatter of the next); then compound 1.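

In this assay, phenyl in place of thiophen-2-yl on the aromatic carbon next to the ring nitrogen gives a 1.5-fold higher number from compound 2 to compound 3 (0.17 log units; within the scatter), so these two aromatic rings cannot be told apart at this position in this assay. Within the data shown here, compound 3 also gives the first reading of a single change on the amide-type nitrogen: the group of 9 heavy atoms in place of the group of 5 heavy atoms gives a 2.7-fold lower number from compound 1 to compound 3 (0.43 log units; beyond the scatter), a modest step beyond the scatter. No measurement at hand bears on the reason for either step.

What the compounds shown leave open is whether this position keeps the same level with a non-aromatic group such as morpholine or a small chain such as methyl, since only aromatic rings stand there so far. Also open, going by these compounds, is whether an amine or a carboxylic acid on the phenyl ring would shift the number.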